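The source may hold more compounds than are shown below. What is called first, only, known or untested is meant among the compounds shown, and "the series" means these compounds.

Among the compounds with values here, compound 1 `Cc1nc2ccc(CNc3ccc(C(=O)N[C@@H](CCC(=O)O)C(=O)O)cc3F)cc2c(=O)[nH]1` gives 120 nM in a functional assay on L1210 cells (Mus musculus) for inhibition (a higher number here means a weaker inhibitor, a lower number a stronger inhibitor), the higher of the two numbers measured so far. Compound 2 `C#CCN(Cc1ccc2nc(C)[nH]c(=O)c2c1)c1ccc(C(=O)N[C@@H](CCC(=O)O)C(=O)O)c(F)c1` gives 27 nM in this assay, a lower number that lies beyond the usual scatter. Compound 3 `CCN(Cc1ccc2nc(C)[nH]c(=O)c2c1)c1ccc(C(=O)N[C@@H](CCC(=O)O)C(=O)O)cc1F` has not yet been measured; it differs from compound 1 by ethyl in place of hydrogen on a nitrogen on an aromatic ring. Within the data shown here, no measured pair shows this exact change, so the size of its step is open. Compound 3 is expected to give a lower number than compound 1, a modest step of a 2.7-fold lower number from compound 1 to compound 3 (0.43 log units; beyond the scatter) in this assay. Compound 3 is estimated at 45 nM, within a range of 18 nM to 120 nM.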

Compound 3, half-maximal inhibitory concentration: 86 nM
Estimate against measurement, compound 3: 1.9-fold (0.28 log units) below; the measured number falls inside the stated range.
By their numbers in this assay, from the lowest: compound 2; then compounds 3 and 1 (each within the scatter of the next).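

In this assay the step is a 1.4-fold lower number from compound 1 to compound 3 (0.14 log units; within the scatter), so ethyl in place of hydrogen on a nitrogen on an aromatic ring leaves the number within the scatter. Compound 2 could not show this, as it differs from compound 1 in more than one place. Nothing available accounts for this result. Still open, going by these compounds, is whether a longer chain, an amine or a carboxylic acid on this nitrogen would move the number beyond the scatter.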